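Compound 1 and its sulfur-bearing counterpart, compound 4

The compounds below may be only part of what the source reports. "The series", "measured", "known", "first", "only" and "open" are said of these compounds alone.

Measured in a functional assay on HeLa cells (Homo sapiens) for inhibition, read by CCK-8 assay, with a stated time of 48 h; on this read-out lower numbers stand for stronger inhibition and higher numbers for weaker inhibition:
Compound 1 `O=C(NCCNS(=O)(=O)c1ccc(-c2ccccc2O[C@H]2CC[C@H](O)CC2)s1)Nc1ccc([N+](=O)[O-])cc1`: 10500 nM
Compound 2 `O=C(NCCNS(=O)(=O)c1ccc(-c2ccccc2Oc2ccc([N+](=O)[O-])c([N+](=O)[O-])c2)s1)Nc1ccc([N+](=O)[O-])cc1`: > 20000 nM (a limit)
Compound 3 `Cc1cc(C)cc(NC(=O)NCCNS(=O)(=O)c2ccc(-c3ccccc3OCc3cccc(O)c3)s2)c1`: > 20000 nM (a limit)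

Among the measured compounds shown here, compound 1 holds the only true number in this small set. Compound 2 gives > 20000 nM, which is a limit of the assay and not a number. Compound 3 gives > 20000 nM, which is likewise a limit.

Compound 4 `O=[N+]([O-])c1ccc(NC(=S)NCCNS(=O)(=O)c2ccc(-c3ccccc3O[C@H]3CC[C@H](O)CC3)s2)cc1` departs from compound 1 in one place: a group of 12 heavy atoms (7 carbon, 2 nitrogen, 2 oxygen, 1 sulfur; one six-membered aromatic ring of carbon only) in place of a group of 12 heavy atoms (7 carbon, 2 nitrogen, 3 oxygen; one six-membered aromatic ring of carbon only), on an amine nitrogen. For the measured compounds named here, the only measured step, an at least 1.9-fold higher number from compound 1 to compound 2 (0.27 log units; that floor lies within the scatter), falls on an oxygen on an aromatic ring, not on the amine nitrogen, so it says little about this change. Going by the values given here, no measured step therefore supports a shift in either direction, and the expected result is no change beyond the scatter: a 1.1-fold lower number from compound 1 to compound 4 (0.02 log units; within the scatter). Compound 4 could also end at the limit of > 20000 nM in this assay, at which 2 of the 3 values shown sit, so a limit in place of a number would be no surprise. For compound 4 the expected value is 10000 nM, with an estimated range from 4000 nM to 20000 nM.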

Compound 4, half-maximal inhibitory concentration: 5400 nM
Compound 4: the middle estimate sits 1.9-fold (0.27 log units) above what was measured; measured number inside the range.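

In this assay, the first step measured on the amine nitrogen is a 1.9-fold lower number from compound 1 to compound 4 (0.29 log units; within the scatter), so the change from the (4-nitrophenyl)carbamoyl group to its sulfur-bearing counterpart gives no shift that can be told from the scatter. Compound 4 also gives a true number and not a limit, which adds a second reading to that of compound 1 on the same shared core. Compound 4 therefore does not join the compounds held at the limit: the limit of > 20000 nM in this assay, at which 2 of the 4 values shown sit.

This single pair does not show whether the same change would behave alike with a different group on the oxygen of the shared core. It also leaves open what an amine or a carboxylic acid in place of the nitro group, or a longer chain on the amine nitrogen, would do to the read-out.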